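Methoxy for Chloro: From Compound 2 to Compound 3

The compounds below may be only part of what the source reports. "The series", "measured", "known", "first", "only" and "open" are said of these compounds alone.

Measured compounds:
compound 1, `Fc1ccccc1Oc1cccc(F)c1C1CCNCC1`, 278 nM
compound 2, `Clc1ccccc1Oc1ncccc1C1CCNCC1`, 5150 nM

Both were measured in an assay on HEK293 cells for displacement of a labelled ligand from sodium-dependent dopamine transporter (Homo sapiens), read by scintillation proximity assay; a lower number here means a stronger inhibitor, a higher number a weaker inhibitor. Compound 2 stands highest of the two numbers, and its nearest neighbour, compound 1, sits at a markedly lower value, a gap beyond the usual scatter. Compound 3, `COc1ccccc1Oc1ncccc1C1CCNCC1`, is not yet measured. It differs from compound 2 in one place: methoxy in place of chloro on an aromatic carbon. Among the compounds with values here, no step between measured compounds shows what this exchange does here. Compound 3 is therefore expected to land near compound 2, with the step of a 1.4-fold higher number from compound 2 to compound 3 (0.13 log units; within the scatter) expected to be small, if anything toward a weaker inhibitor. The estimate for compound 3 in this assay is 7000 nM, within 2500 nM to 20000 nM.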

Compound 3, inhibition constant: 6410 nM
For compound 3 the middle estimate is 1.1-fold (0.04 log units) above the measured one, within the range that was stated.
By their numbers in this assay, from the lowest: compound 1; then compounds 2 and 3 (each within the scatter of the next).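

In this assay, methoxy in place of chloro on an aromatic carbon, ortho to a large group, gives a 1.2-fold higher number from compound 2 to compound 3 (0.10 log units; within the scatter) and so lies within the scatter. Within the data shown here, this is the first step that can be read at this place, and it does not tell the two groups apart, although methoxy has 1 hydrogen-bond acceptor and chloro has none. Open, on these data alone, is whether an amine, a carboxylic acid or a longer chain such as butoxy at this place would read the same, or whether this exchange would on the core of compound 1. No measurement shown bears on why these two groups read alike.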